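Dithiocarbamate chromones: changing the amine of compound 1

This account rests on a few compounds, and the source may have more. Where it says the series, first, only, none or still open, it means among the compounds named here.

Measured so far:
compound 1, `O=c1c(CSC(=S)N2CCOCC2)coc2cc(Cl)ccc12`: 600 nM
compound 2, `CC(C)N(C(=S)SCc1cc(=O)c2ccc(Cl)cc2o1)C(C)C`: > 25000 nM

Among the measured compounds shown here, in a functional assay on MDA-MB-435S cells (Homo sapiens) for antiproliferative activity, read by MTT assay, with a stated time of 72 h (a higher number here means a weaker inhibitor, a lower number a stronger inhibitor), compound 1 gives 600 nM, the only numerical value in the set. For compound 2 the assay reports only a limit, > 25000 nM; this is the limit of > 25000 nM in this assay, at which 1 of the 2 values shown sits. Compound 3, `CC(C)N(C(=S)SCc1coc2cc(Cl)ccc2c1=O)C(C)C`, carries diisopropylamino in place of morpholin-4-yl on a thiocarbonyl carbon. For the measured compounds named here, no measured pair isolates this change, so the expected step from compound 1 to compound 3 is set at a 5.0-fold higher number from compound 1 to compound 3 (0.70 log units; beyond the scatter), a loss beyond the usual scatter, with wide uncertainty. Compound 3 is accordingly estimated at 3000 nM, in the range 600 nM to 25000 nM.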

Compound 3, half-maximal inhibitory concentration: > 25000 nM
Compound 3: only a limit was reported; the forecaster's own chance of this, stated with the estimate: 30%; middle value at least 8.3-fold (0.92 log units) away from the limit.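

Among the compounds shown here, this is the first pair that isolates the amine on the thiocarbonyl carbon. In this assay, diisopropylamino in place of morpholin-4-yl gives an at least 41-fold higher number from compound 1 to compound 3 (1.61 log units; beyond the scatter), a large loss. The value for compound 3 is a limit, not a number, so the step has no upper bound: the limit of > 25000 nM in this assay, at which 2 of the 3 values shown sit.

The compounds shown leave open whether the ring of morpholin-4-yl or its oxygen is what matters on this carbon. Piperidin-1-yl, which keeps a ring without that oxygen, and diethylamino, a smaller open-chain amine, would help to separate the two.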